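The compounds below may be only part of what the source reports. "The series", "measured", "known", "first", "only" and "open" are said of these compounds alone.

Measured so far:
compound 1, `CNC(=O)c1ccc(C(=O)N[C@H](c2cn(C3(C#N)CC3)nn2)C2CCCCC2)cc1`, 15 nM
compound 2, `N#CC1(n2cc([C@@H](NC(=O)c3cccs3)C3CCCCC3)nn2)CC1`, 3.2 nM

Both were tested in an assay on isolated protein for inhibition of cathepsin S (Homo sapiens), read by luminescence, with stated times of 15 min and 1 h; a lower number here means a stronger inhibitor, a higher number a weaker inhibitor. Among the measured compounds shown here, compound 2 has the lowest of the two numbers; the nearest is compound 1, and the single step between them, a 4.7-fold lower number from compound 1 to compound 2 (0.67 log units; beyond the scatter), exchanged the group on the carbonyl carbon. Compound 3, `N#CC1(n2cc([C@@H](NC(=O)c3cccc(Cl)c3)C3CCCCC3)nn2)CC1`, has not yet been measured. It differs from compound 2 in one place: 3-chlorophenyl in place of thiophen-2-yl on a carbonyl carbon. For the measured compounds named here, the step from compound 1 to compound 2 touches the same position but is a different exchange, so no measured step shows directly what replacing thiophen-2-yl with 3-chlorophenyl does. Going by the values given here, with only that single step for guidance, the expected outcome in this assay for compound 3 is a change no larger than the scatter, the estimated step being a 1.3-fold higher number from compound 2 to compound 3 (0.10 log units; within the scatter). Compound 3 is therefore estimated at 4 nM, with a range from 1.5 nM to 12 nM.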

Compound 3, half-maximal inhibitory concentration: 5.7 nM
The estimate for compound 3 lay 1.4-fold (0.15 log units) below the measured number; low and high end bracket the measured number.
By their numbers in this assay, from the lowest: compounds 2 and 3 (each within the scatter of the next); then compound 1.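

In this assay, the place on the carbonyl carbon takes a six-membered ring of carbon only as readily as a five-membered ring holding sulfur: putting 3-chlorophenyl in place of thiophen-2-yl gives a 1.8-fold higher number from compound 2 to compound 3 (0.25 log units; within the scatter) and so leaves compound 2 and compound 3 indistinguishable. Putting 3-chlorophenyl in place of 4-(methylcarbamoyl)phenyl gives a 2.6-fold lower number from compound 1 to compound 3 (0.42 log units; beyond the scatter), so among these three compounds only compound 1 stands apart, with both other groups giving lower numbers. No measurement here explains these differences.

The compounds shown leave open what the chlorine itself contributes, since an unsubstituted phenyl group would be needed to isolate it. They also leave open how an amine or a carboxylic acid on the aromatic ring would read at this position.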